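A Larger Group on the Oxygen of Compound 2

This account rests on a few compounds, and the source may have more. Where it says the series, first, only, none or still open, it means among the compounds named here.

Of the compounds shown here, two of one series have been measured in a physicochemical assay for lipophilicity, measured as octanol-water partition; a higher number here means a more lipophilic compound, a lower number a more polar compound. Compound 1 `CCO/N=C/Nc1cc(Cl)c(OCCCl)c(Cl)c1` gives 4 in this assay. For the measured compounds named here, compound 2 `C#CCO/N=C/Nc1cc(Cl)c(CC#C)c(Cl)c1` gives 3.3 in this assay, which leaves compound 2 as the lower of the two numbers, with compound 1 as its only neighbour and the gap between them lying beyond the scatter. Compound 3 `C#CCc1c(Cl)cc(N/C=N/Oc2ccc(C)cc2)cc1Cl` has not yet been measured in this assay. It differs from compound 2 in one place: 4-methylphenyl in place of propargyl on an oxygen. Going by the values given here, no pair of measured compounds shows a step of this kind, so its size has to be estimated from the change alone. The group entering is larger than the group leaving, and compound 3 is therefore expected to move upward in this assay by a step of a number 1.50 log units higher from compound 2 to compound 3 (beyond the scatter) that lies beyond the scatter. The estimate for compound 3 in this assay is 4.8, expected to fall between 4.2 and 5.4.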

Compound 3, partition coefficient: 4.8
The estimate for compound 3 equals the measured number at the digits printed, and the stated range covers the measured number.
By their numbers in this assay, from the lowest: compound 2; then compound 1; then compound 3.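

In this assay, for the compounds shown here, the exchange of propargyl for 4-methylphenyl, on an oxygen whose other neighbours are the double-bonded nitrogen, gives a number 1.50 log units higher from compound 2 to compound 3 (beyond the scatter) and so provides the first step that can be tied to a single change. It shows that the number in this assay is not indifferent to the group on this oxygen, and that an aromatic ring of carbon only can stand there in place of a chain with a triple bond. Nothing among the data gives a reason for the size of this step.

The compounds shown leave open how much of the step belongs to the ring itself and how much to its methyl, which an unsubstituted phenyl would separate. They also leave open how the number would move with a ring carrying an amine or a carboxylic acid on this oxygen.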